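The source may hold more compounds than are shown below. What is called first, only, known or untested is meant among the compounds shown, and "the series" means these compounds.

Measured in an in vitro ADME assay on microsomes from liver (Homo sapiens) for pharmacokinetics, read by LC-MS, with a stated time of 10 min, tested at 1 uM; on this read-out higher numbers stand for fast clearance and lower numbers for slow clearance:
- compound 1 `CN1C[C@H](C(=O)Nc2ccc(C(F)(F)F)cc2)[C@@H](c2ccc(/C=C/C(=O)Nc3ccccc3N)cc2)C1`: 6 mL/min/kg
- compound 2 `CN1C[C@H](C(=O)Nc2ccc(Br)cc2)[C@@H](c2ccc(/C=C/C(=O)Nc3ccccc3N)cc2)C1`: 3 mL/min/kg
- compound 3 `CN1C[C@H](C(=O)Nc2ccccc2F)[C@@H](c2ccc(/C=C/C(=O)Nc3ccccc3N)cc2)C1`: 10 mL/min/kg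

Compound 3 stands at 10 mL/min/kg. It is set apart only from compound 2, with a 3.3-fold higher number from compound 2 to compound 3 (0.52 log units; beyond the scatter), while the data show a 1.7-fold higher number from compound 1 to compound 3 (0.22 log units; within the scatter).

Compound 4 `CN1C[C@H](C(=O)Nc2ccc(Cl)c(Cl)c2)[C@@H](c2ccc(/C=C/C(=O)Nc3ccccc3N)cc2)C1` carries 3,4-dichlorophenyl in place of 2-fluorophenyl on an amide-type nitrogen. Among the compounds with values here, no measured step involves this group. The two nearest steps are those above, which bring in 2-fluorophenyl at the same place. Read backwards, they point to a modest fall in this assay, and the expected size lies between them. The estimated change is a 2.2-fold lower number from compound 3 to compound 4 (0.35 log units; beyond the scatter). Compound 4 is expected at 4.5 mL/min/kg, with an estimated range of 2 mL/min/kg to 9 mL/min/kg.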

Compound 4, clearance: 14 mL/min/kg
The estimate for compound 4 lay 3.1-fold (0.49 log units) below the measured number; measured number outside the range, above it.
By their numbers in this assay, from the lowest: compounds 2, 1, 3 and 4 (each within the scatter of the next, the first and the last beyond it).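

In this assay, within the data shown here, the 3,4-dichlorophenyl group on the amide-type nitrogen gives a 2.3-fold higher number from compound 1 to compound 4 (0.37 log units; beyond the scatter), the first step beyond the scatter that involves the 4-(trifluoromethyl)phenyl group. It also gives a 4.7-fold higher number from compound 2 to compound 4 (0.67 log units; beyond the scatter), whereas a 1.4-fold higher number from compound 3 to compound 4 (0.15 log units; within the scatter) leaves 3,4-dichlorophenyl and 2-fluorophenyl unseparated, so 4-bromophenyl remains the group set apart from these two. Nothing available bears on why these groups differ. Open, on these data alone, is how a phenyl carrying a single chlorine would compare, since only compound 4 carries chlorine. Also open, as far as these compounds go, is what a phenyl bearing an amine or a carboxylic acid would give at this place.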